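A few compounds are considered here, and "the series" means these few. Any claim that something is new, unique, unknown or untested is made for them only; others in the source may bear on it.

Measured in an ADME assay on the whole organism (plasma, strain Sprague-Dawley) for pharmacokinetics, with Rattus norvegicus as the target, at a dose of 5 mg/kg by the oral route; on this read-out higher numbers stand for higher exposure at the dose given and lower numbers for lower exposure:

Compound 1 `Cc1c(Cl)cc2[nH]c(=O)c(=O)[nH]c2c1N(CC(=O)O)S(C)(=O)=O` gives 1500 ng.h/mL
Compound 2 `CCc1c(Cl)cc2[nH]c(=O)c(=O)[nH]c2c1N(CCO)S(C)(=O)=O` gives 183 ng.h/mL

Of these two numbers, the lower belongs to compound 2, and its gap to compound 1 lies beyond the scatter. Compound 3 `Cc1c(Cl)cc2[nH]c(=O)c(=O)[nH]c2c1N(CCO)S(C)(=O)=O` is compound 2 with one change, (hydrogen in place of methyl on a saturated chain carbon bound to an aromatic carbon), hydrogen in place of methyl on a saturated chain carbon bound to an aromatic carbon, so that ethyl becomes methyl. Going by the values given here, no measured pair shows this change, so only a small rise in this assay is expected, one probably within the scatter. The estimated change is a 1.4-fold higher number from compound 2 to compound 3 (0.14 log units; within the scatter). The estimate for compound 3 is 250 ng.h/mL, with an expected range from 90 ng.h/mL to 700 ng.h/mL.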

Compound 3, area under the concentration-time curve in the Rattus norvegicus assay: 605 ng.h/mL
The estimate for compound 3 lay 2.4-fold (0.38 log units) below the measured number; measured number inside the range.
By their numbers in the Rattus norvegicus assay, from the lowest: compound 2; then compound 3; then compound 1.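

Going by these compounds alone, in the Rattus norvegicus assay, compound 1 gives 1500 ng.h/mL, compound 2 gives 183 ng.h/mL and compound 3 gives 605 ng.h/mL; ethyl to methyl on a saturated chain carbon bound to an aromatic carbon gives a 3.3-fold higher number from compound 2 to compound 3 (0.52 log units; beyond the scatter) as a single change, and hydroxymethyl in place of carboxy gives a 2.5-fold lower number from compound 1 to compound 3 (0.39 log units; beyond the scatter) on its own, so the two changes that separated the earlier compounds can now be read apart. In a physicochemical assay for solubility (on this read-out lower numbers stand for lower solubility and higher numbers for higher solubility), compound 2 gives 72 ug/mL and compound 3 gives 70 ug/mL, and the ethyl to methyl change gives a 1.0-fold lower number from compound 2 to compound 3 (0.01 log units; within the scatter) and so offers no parallel to the exposure step. Nothing available explains that step here.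

From the compounds shown here alone, whether a propyl chain at the first place or an amide in place of carboxy would shift exposure further remains open.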